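This account rests on a few compounds, and the source may have more. Where it says the series, first, only, none or still open, it means among the compounds named here.

Measured in an assay on microsomes from intestine for inhibition of acyl-CoA:cholesterol acyltransferase (Oryctolagus cuniculus); on this read-out lower numbers stand for stronger inhibition and higher numbers for weaker inhibition:

compound 1, `CC(C)c1cccc(C(C)C)c1NC(=O)NCCCc1ccccc1`, gives 191 nM
compound 2, `CC(C)c1cccc(C(C)C)c1NC(=O)NC(c1ccccc1)c1ccccc1`, gives 45 nM
compound 3, `CC(C)c1cccc(C(C)C)c1NC(=O)NCC1(c2cccnc2)CCCC1`, gives 97 nM

Compound 3 sits between the other two numbers in this assay: compound 1 lies within the scatter of compound 3, so no order can be read between those two, while compound 2 lies beyond the scatter with the lower number of the three shown.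

Compound 4, `CC(C)c1cccc(C(C)C)c1NC(=O)NCC1(c2cccc3ccccc23)CCCC1`, differs from compound 3 in one place: naphthalen-1-yl in place of pyridin-3-yl on a saturated ring carbon. The shared core is unchanged, as is the five-membered ring.

No step between measured compounds isolates this kind of change, so expectation rests on the numbers shown. Compound 2 shows that an arrangement built of aromatic carbon rings only can reach the lowest number in this assay, because compound 2 gives 45 nM. The entering group adds aromatic carbon and removes the acceptor, so a modest step toward a lower number, a 1.8-fold lower number from compound 3 to compound 4 (0.25 log units; within the scatter), is expected for compound 4, though it may stay within the scatter. Compound 4 is therefore estimated at 55 nM, with a range from 20 nM to 150 nM.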

Compound 4, half-maximal inhibitory concentration: 34 nM
Compound 4: middle estimate off by 1.6-fold (0.21 log units), on the high side; low and high end bracket the measured number.
By their numbers in this assay, from the lowest: compounds 4 and 2 (each within the scatter of the next); then compounds 3 and 1 (each within the scatter of the next).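

On the saturated ring carbon of the five-membered ring, the larger group is accepted in this assay: a 2.9-fold lower number from compound 3 to compound 4 (0.46 log units; beyond the scatter). For the compounds shown here, this is the first step that isolates one place, and it shows that pyridin-3-yl and its hydrogen-bond acceptor are not required there for a lower number. Nothing measured gives a reason for the step.

The single change adds a second aromatic ring and removes the ring nitrogen together, and these two parts cannot be separated from the compounds shown; a quinolinyl group on the same carbon would carry the second ring and keep a ring nitrogen. Also open, going by these compounds, is whether the step would hold on a six-membered ring of carbon only in place of the five-membered ring.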